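A few compounds are considered here, and "the series" means these few. Any claim that something is new, unique, unknown or untested is made for them only; others in the source may bear on it.

Notes on the series. Compound 1 `CNC(=O)CCC(CC(=O)Nc1ccc(C)cc1C)c1nnc(CCCC(C)C)n1C1CC1` gives 3.5 in a physicochemical assay for lipophilicity; on this read-out lower numbers stand for lower lipophilicity and higher numbers for higher lipophilicity. Within the data shown here, compound 2 `Cc1ccc(NC(=O)CC(CCC(=O)N(C)C)c2nnc(CCCC(C)C)n2C2CC2)c(C)c1` gives 3.8 in this assay; the one single-point step measured within the set, a number 0.30 log units higher from compound 1 to compound 2 (within the scatter), is methyl in place of hydrogen on an amide-type nitrogen. Compound 3 `Cc1ccc(NC(=O)C[C@H](CCC(=O)O)c2noc(-c3ccc(CC(C)C)cc3)c2C2CC2)c(Cl)c1` gives 4.8 in this assay, the highest of the three numbers, standing beyond the scatter from both compound 2 and compound 1.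

Compound 4 `Cc1ccc(NC(=O)C[C@H](CCC(=O)O)c2noc(-c3cc(CCC(C)C)on3)c2C2CC2)c(Cl)c1` has not yet been measured. It differs from compound 3 in one place: 5-isopentyl-1,2-oxazol-3-yl in place of 4-isobutylphenyl on an aromatic carbon. The entering group sits on an aromatic carbon of a five-membered aromatic ring with 1 nitrogen and 1 oxygen, next to the ring oxygen and next to the ring atom that bears a cyclopropyl group. Among the measured compounds shown here, no measured step in the set bears on this exchange; the only step available, a number 0.30 log units higher from compound 1 to compound 2 (within the scatter), concerns another part of the molecule and stays within the scatter, so it gives no guide to direction or size here. The exchange of a six-membered aromatic ring of carbon only for a five-membered aromatic ring with 2 hetero atoms, with isopentyl in place of isobutyl, is expected to lower the number moderately: a step of a number 0.50 log units lower from compound 3 to compound 4 (beyond the scatter) is estimated. Compound 4 is therefore expected at 4.3, within a range from 3.7 to 4.9.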

Compound 4, distribution coefficient: 4.3
Compound 4: middle estimate and measured number agree at the digits printed; low and high end bracket the measured number.
By their numbers in this assay, from the lowest: compounds 1 and 2 (each within the scatter of the next); then compound 4; then compound 3.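

In this assay, among these compounds, the exchange of 4-isobutylphenyl for 5-isopentyl-1,2-oxazol-3-yl gives a number 0.50 log units lower from compound 3 to compound 4 (beyond the scatter), the only step in the set that lies beyond the scatter and the only one at this position, on an aromatic carbon of a five-membered aromatic ring with 1 nitrogen and 1 oxygen. The number moves here while the heavy-atom count of the group stays the same: the entering group holds 8 carbon, 1 nitrogen and 1 oxygen where the leaving group holds carbon only, one six-membered aromatic ring of carbon only gives way to one five-membered aromatic ring with 2 hetero atoms, hydrogen-bond acceptors go from 0 to 2, and neither group carries a net charge. No measurement in hand accounts for this step.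

The ring and the chain change together in this single step, so the compounds shown do not separate the part of the ring exchange from that of isopentyl in place of isobutyl, which a 4-isopentylphenyl or a 5-isobutyl-1,2-oxazol-3-yl group at the same place would address. On these data alone, whether the step carries over to other groups at this position, such as a pyridine ring or a phenyl ring bearing an aminomethyl chain, also remains open.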